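Thioether in Place of Benzylamine on a Shared Core

A few compounds are considered here, and "the series" means these few. Any claim that something is new, unique, unknown or untested is made for them only; others in the source may bear on it.

Compound 1, `Nc1cc(N)c2nc(-c3ccccc3)c(NCc3ccc(Cl)c(Cl)c3)nc2c1`, gives 4270 nM in a functional assay on SK-MEL-2 cells (Homo sapiens) for inhibition, read by sulforhodamine B assay, with a stated time of 48 h; on this read-out higher numbers stand for weaker inhibition of growth and lower numbers for stronger inhibition of growth.
Compound 2, `Nc1cc(N)c2nc(-c3ccccc3)c(NCc3ccc(F)cc3)nc2c1`, gives only a limit in this assay, namely < 100000 nM.
Compound 3, `COc1ccc(CNc2nc3cc(N)cc(N)c3nc2-c2ccccc2)cc1`, gives 28800 nM in this assay.

Compound 2 stands among these values as a limit of the assay and not as a number. The steps a step that the limit leaves unreadable from compound 1 to compound 2 and a step that the limit leaves unreadable from compound 2 to compound 3 are unreadable because of the limit of < 100000 nM in this assay, at which 1 of the 3 values shown sits. Among the measured compounds shown here, the one readable step is a 6.7-fold higher number from compound 1 to compound 3 (0.83 log units; beyond the scatter), a modest loss of growth inhibition when the methoxy-bearing ring replaces the dichlorinated one.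

Compound 4, `Nc1cc(N)c2nc(-c3ccccc3)c(Sc3ccc(F)cc3)nc2c1`, is the next compound. It differs from compound 2 by (4-fluorophenyl)sulfanyl in place of (4-fluorobenzyl)amino on an aromatic carbon. For the measured compounds named here, none of the measured steps replaces the (4-fluorobenzyl)amino group itself; all three exchange groups on the attached ring. Going by the values given here, no measured step therefore bears on this change, and the starting point is only a limit. The expected step is a step that the limit leaves unreadable from compound 2 to compound 4, held with little confidence. Compound 4 is estimated at 30000 nM, with a range from 4000 nM to 100000 nM.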

Compound 4, concentration for total growth inhibition: < 100000 nM
Compound 4: only a limit was reported (the forecaster's own chance of this, stated with the estimate: 40%); the middle value does not contradict the limit.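

No step can be read from compound 2 to compound 4, because each gives only a limit and not a number: the limit of < 100000 nM in this assay, at which 2 of the 4 values shown sit.

As far as these compounds go, whether (4-fluorophenyl)sulfanyl in place of (4-fluorobenzyl)amino on the shared core strengthens or weakens growth inhibition in this assay stays open.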